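Swapping the Amide Amine: From Compound 3 to Compound 4

The source may hold more compounds than are shown below. What is called first, only, known or untested is meant among the compounds shown, and "the series" means these compounds.

Of the compounds shown here, three that share a core have been tested in an assay on the whole organism (plasma, strain Sprague-Dawley) for inhibition of Dipeptidyl peptidase 4 (Rattus norvegicus), with a stated time of 10 h, at a dose of 1 mg/kg by the oral route; a higher number here means more inhibition at the dose given (going by the name of the read-out), a lower number less inhibition. Compound 1 `N#C[C@@H]1CCCN1C(=O)[C@@H]1C[C@H](C(=O)N2CCOCC2)CN1` gives 44%, compound 2 `C[C@@H]1N[C@H](C(=O)N2CCC[C@H]2C#N)C[C@@H]1C(=O)N1CCC1` gives 88%, and compound 3 `CCN(C)C(=O)[C@H]1C[C@@H](C(=O)N2CCC[C@H]2C#N)N[C@H]1C` gives 79%. Compound 3 therefore stands second highest of the three: the gap to compound 2 is within the scatter, while compound 1 sits far below it, beyond the scatter.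

Within the data shown here, the one measured step that changes the same amide amine is the one a number 9 percentage points lower from compound 2 to compound 3 (within the scatter), which stays within the scatter. Among the measured compounds shown here, that is the only direct precedent for altering this group.

The untested compound 4 `C[C@@H]1N[C@H](C(=O)N2CCC[C@H]2C#N)C[C@@H]1C(=O)N1CCOCC1` differs from compound 3 in just this place: morpholin-4-yl in place of ethyl(methyl)amino on a carbonyl carbon. Compound 1 also carries a morpholin-4-yl on its amide, but its core lacks the methyl of compound 3, so its value alone cannot be read as a step for this change.

Given that the only comparable step was small, a change a number 5 percentage points lower from compound 3 to compound 4 (within the scatter) is expected to stay within the scatter. Compound 4 is estimated to reach 74% in this assay, with a plausible range from 55% to 90%.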

Compound 4, a percentage reported as inhibition, in the whole organism at one dose (the size of the read-out at that dose, not a potency): 85%
The estimate for compound 4 lay 11 percentage points below the measured number; measured number inside the range.
By their numbers in this assay, from the lowest: compound 1; then compounds 3, 4 and 2 (each within the scatter of the next).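

In this assay, this position on the carbonyl carbon accepts a third amine without a clear shift in the read-out. The step of a number 6 percentage points higher from compound 3 to compound 4 (within the scatter) and the step of a number 3 percentage points lower from compound 2 to compound 4 (within the scatter) both stay small, even though morpholin-4-yl brings a six-membered ring and a hydrogen-bond acceptor that ethyl(methyl)amino lacks. Among these compounds, compound 4 also gives the first comparison with compound 1 that differs in one place, and the step of a number 41 percentage points higher from compound 1 to compound 4 (beyond the scatter), with methyl in place of hydrogen on a saturated ring carbon, shows that the morpholin-4-yl amide can reach a high number, so the low number of compound 1 goes with the missing methyl rather than with this amide. Nothing measured here explains either the small amine steps or the large methyl step.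

The compounds shown leave open whether the position would accept a piperazin-1-yl group, which carries a second ring nitrogen, or a longer chain such as dibutylamino. They also leave open whether the methyl step would be as large with azetidin-1-yl or ethyl(methyl)amino on the carbonyl carbon.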